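Phenyl Substituent Removal on the Shared Core

The source may report more compounds than this note shows. Statements on the series, on what has been measured and on what is new or still open speak of the compounds shown alone.

Measured compounds:
compound 1, `Cc1nc2c3ccccc3ccc2c2nc3c(ccc4ccccc43)c(-c3ccccc3S)c12`: 158 ug/mL
compound 2, `Cc1nc2c3ccccc3ccc2c2nc3c(ccc4ccccc43)c(-c3cccc([N+](=O)[O-])c3)c12`: 157 ug/mL

In a functional assay, with a stated time of 90 s (on this read-out higher numbers stand for weaker inhibition and lower numbers for stronger inhibition), compound 1 gives 158 ug/mL and stands at the top of the two numbers, with compound 2 at 157 ug/mL within the scatter of it. Going by the values given here, the single measured step, a 1.0-fold lower number from compound 1 to compound 2 (0.00 log units; within the scatter), changes the group carried by the phenyl ring and does not move the number beyond the scatter.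

Compound 3, `Cc1nc2c3ccccc3ccc2c2nc3c(ccc4ccccc43)c(-c3ccccc3)c12`, remains to be measured in this assay. It differs from compound 1 by hydrogen in place of sulfanyl on an aromatic carbon. Among the compounds with values here, the only step bearing on this change is a 1.0-fold lower number from compound 1 to compound 2 (0.00 log units; within the scatter), which also alters what the phenyl ring carries and gave no movement beyond the scatter. No step beyond the scatter is therefore expected in this assay, in either direction. For compound 3 the estimate is 160 ug/mL, with a range from 80 ug/mL to 320 ug/mL. The expected step is thus a 1.0-fold higher number from compound 1 to compound 3 (0.01 log units; within the scatter).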

Compound 3, half-maximal inhibitory concentration: 188 ug/mL
Estimate against measurement, compound 3: 1.2-fold (0.07 log units) below, within the range that was stated.
By their numbers in this assay, from the lowest: compounds 2, 1 and 3 (each within the scatter of the next).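

In this assay, compound 3 carries the bare phenyl ring, so sulfanyl and nitro can each be read directly against hydrogen on the shared core. Replacing sulfanyl, on the aromatic carbon ortho to a large group, gives (a 1.2-fold higher number from compound 1 to compound 3 (0.08 log units; within the scatter)), and replacing nitro gives (a 1.2-fold higher number from compound 2 to compound 3 (0.08 log units; within the scatter)), so among these three compounds neither group is separated from hydrogen on this read-out. No measured evidence on the origin of this flat result is available.

Sulfanyl and nitro occupy different places on the phenyl ring, so the compounds shown do not test a single group across places on that ring. From the compounds shown here alone, whether an amine or a carboxylic acid on the ring, or a longer chain in place of the ring, would give a step beyond the scatter remains open.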